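Swapping the benzyl thioether for a short alkyl chain

The source may hold more compounds than are shown below. What is called first, only, known or untested is meant among the compounds shown, and "the series" means these compounds.

Measured in a functional assay on A549 cells (Homo sapiens) for antiproliferative activity, read by CCK-8 assay, with a stated time of 48 h; a higher number here means a weaker inhibitor, a lower number a stronger inhibitor:
compound 1, `CC(C)CSc1n[nH]c(-n2[se]c3ccccc3c2=O)n1`: 37800 nM
compound 3, `O=c1c2ccccc2[se]n1-c1nc(SCc2ccc(Cl)cc2)n[nH]1`: 42100 nM
compound 2, `Cc1ccc(CSc2n[nH]c(-n3[se]c4ccccc4c3=O)n2)cc1`: > 50000 nM, which is a limit of the assay rather than a number.

All three compounds share the same core and differ only in the group on a saturated chain carbon bound to a sulfur. Compound 2 stands at the limit of > 50000 nM in this assay, at which 1 of the 3 values shown sits, so its position relative to the other two can only be bounded, not fixed. Compound 4, `CCCSc1n[nH]c(-n2[se]c3ccccc3c2=O)n1`, has not been measured yet. The change from compound 2 to compound 4 is ethyl in place of 4-methylphenyl on a saturated chain carbon bound to a sulfur, which brings the substituent close to the short branched chain of compound 1.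

Among the compounds with values here, two measured steps bear on this. The step of an at least 1.3-fold higher number from compound 1 to compound 2 (0.12 log units; that floor lies within the scatter) and the step of a 1.1-fold higher number from compound 1 to compound 3 (0.05 log units; within the scatter) show that replacing the branched chain with either aryl-bearing group moved the number little. The step of an at least 1.1-fold lower number from compound 2 to compound 3 (0.07 log units; that floor lies within the scatter) is likewise small. Returning from the aryl-bearing group to a plain chain is therefore expected to give, at most, a modest move toward a lower number, as in an at least 1.3-fold lower number from compound 2 to compound 4 (0.11 log units; that floor lies within the scatter). Compound 4 is estimated at 38000 nM, with a likely range from 15000 nM to 100000 nM.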

Compound 4, half-maximal inhibitory concentration: 45500 nM
For compound 4 the middle estimate is 1.2-fold (0.08 log units) below the measured one; the measured number falls inside the stated range.
By their numbers in this assay, from the lowest: compounds 1, 3 and 4 (each within the scatter of the next). At a limit, above all of these: compound 2.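

In this assay, an ethyl on the saturated chain carbon bound to a sulfur gives a number that cannot be told apart from the one given by a 4-chlorophenyl at that place (a 1.1-fold higher number from compound 3 to compound 4 (0.03 log units; within the scatter)). Losing the methyl from the branched chain also makes no difference beyond the scatter (a 1.2-fold higher number from compound 1 to compound 4 (0.08 log units; within the scatter)), so among compounds 1, 3 and 4, a six-membered aromatic ring at this place is not needed for the activity seen, and neither the plain nor the branched chain stands apart. Compound 2 sits at a limit of the assay, which is not a number, so its step can be read only as a floor that lies within the scatter (an at least 1.0-fold lower number from compound 2 to compound 4 (0.04 log units; that floor lies within the scatter)).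

From the compounds shown here alone, every group compared so far is a plain carbon chain or a carbon-only aromatic ring, and none of them clearly separates one compound from another in this assay, so it remains open whether this place can move the number at all. An amine, a carboxylic acid or a much longer chain such as decyl on this chain carbon would put that question to a different kind of group.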